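This account rests on a few compounds, and the source may have more. Where it says the series, first, only, none or still open, it means among the compounds named here.

Three compounds built on the shared core of compound 1 `COc1cc(-c2cc(C(=O)O)c3ccccc3n2)ccc1OCC(=O)Nc1ccccc1F` have been measured in an ADME assay on HaCaT cells (Homo sapiens) for inhibition; a higher number here means a weaker inhibitor, a lower number a stronger inhibitor. Compound 1 gives 161000 nM, which places it second highest of the three numbers. Compound 2 `COc1cc(-c2cc(C(=O)O)c3ccccc3n2)ccc1OCC(=O)Nc1ccc(F)cc1` gives 286000 nM, and compound 3 `COc1cc(-c2cc(C(=O)O)c3ccccc3n2)ccc1OCC(=O)Nc1ccccc1C(F)(F)F` gives 102000 nM.

Compound 4 `COc1cc(-c2cc(C(=O)O)c3ccccc3n2)ccc1OCC(=O)Nc1cccc(C(F)(F)F)c1` differs from compound 1 in one place: 3-(trifluoromethyl)phenyl in place of 2-fluorophenyl on an amide-type nitrogen. Among the compounds with values here, two measured steps bear on it. The step of a 1.8-fold higher number from compound 1 to compound 2 (0.25 log units; within the scatter) shows that moving the fluoro to another carbon of the phenyl changed little. The step of a 1.6-fold lower number from compound 1 to compound 3 (0.20 log units; within the scatter) shows that putting a trifluoromethyl where the fluoro stood also changed little. Only a 2.8-fold lower number from compound 2 to compound 3 (0.45 log units; beyond the scatter) reached beyond the scatter, and it is modest. Compound 4 combines a new position with a trifluoromethyl, and on these steps no change beyond the scatter is expected in this assay; the expected step is a 1.2-fold lower number from compound 1 to compound 4 (0.09 log units; within the scatter).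

Compound 4 is therefore estimated at 130000 nM, with a range from 55000 nM to 300000 nM.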

Compound 4, half-maximal inhibitory concentration: 160000 nM
Estimate against measurement, compound 4: 1.2-fold (0.09 log units) below; measured number inside the range.
By their numbers in this assay, from the lowest: compounds 3, 4, 1 and 2 (each within the scatter of the next, the first and the last beyond it).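

In this assay, 3-(trifluoromethyl)phenyl on the amide-type nitrogen gives essentially the same number as 2-fluorophenyl (a 1.0-fold lower number from compound 1 to compound 4 (0.00 log units; within the scatter)), so a trifluoromethyl at this new place on the phenyl, with more heavy atoms in the entering group, brings no step beyond the scatter. The steps from the other two compounds also stay within the scatter (a 1.6-fold higher number from compound 3 to compound 4 (0.20 log units; within the scatter); a 1.8-fold lower number from compound 2 to compound 4 (0.25 log units; within the scatter)), so compound 4 lies within the scatter of all three, even though compound 2 and compound 3 differ beyond it. No measurement at hand explains why these changes matter so little.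

All four phenyl groups carry only fluoro or trifluoromethyl, so these compounds leave open what an amine, a nitrile or a carboxylic acid on that phenyl would do. They also leave open whether a longer chain or a saturated ring in place of the phenyl would give a step beyond the scatter.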